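Selenium Replaced by Methylsulfanyl on the Shared Core

The source may report more compounds than this note shows. Statements on the series, on what has been measured and on what is new or still open speak of the compounds shown alone.

Compound 1 `Sc1nc(NCc2ccccc2)c2ccccc2n1` bears a single sulfur atom on an aromatic carbon of the shared core. In a functional assay on CCRF-CEM cells (Homo sapiens) for cytotoxicity, read by MTT assay, with a stated time of 72 h (on this read-out lower numbers stand for stronger inhibition of growth and higher numbers for weaker inhibition of growth), compound 1 gives 82400 nM. Compound 2 `CSc1nc(NCc2ccc([Se]C)cc2)c2ccccc2n1` carries a methylsulfanyl group at that same carbon and, in this assay, gives 63300 nM. Compound 3 `[SeH]c1nc(NCc2ccccc2)c2ccccc2n1` has a selenium atom where compound 1 has sulfur. For compound 3 this assay reports only a limit, > 100000 nM, so compound 3 sits at the limit of > 100000 nM in this assay, at which 1 of the 3 values shown sits. The swap of sulfur for selenium thus gives an at least 1.2-fold higher number from compound 1 to compound 3 (0.08 log units; that floor lies within the scatter), a move that lies within the scatter of repeated measurements.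

Compound 4 `CSc1nc(NCc2ccccc2)c2ccccc2n1` arises from compound 3 by a group of 2 heavy atoms (1 carbon, 1 sulfur; no ring) in place of one selenium atom, on an aromatic carbon. Among the compounds with values here, the only measured step that touches this position is the small selenium-for-sulfur move, and compound 2 shows that a methylsulfanyl group on this core is compatible with a measured value of 63300 nM. Compound 4 is therefore expected to return from the limit to a measured number, a step of about an at least 1.4-fold lower number from compound 3 to compound 4 (0.15 log units; that floor lies within the scatter). The estimate for compound 4 is 70000 nM, with a plausible range from 35000 nM to 150000 nM.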

Compound 4, concentration for 50% growth inhibition: 87900 nM
Compound 4: middle estimate off by 1.3-fold (0.10 log units), on the low side; measured number inside the range.
By their numbers in this assay, from the lowest: compounds 2, 1 and 4 (each within the scatter of the next). At a limit, above all of these: compound 3.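

Within the data shown here, putting methyl on the sulfur of compound 1 is a change not seen in the earlier steps, and it gives a 1.1-fold higher number from compound 1 to compound 4 (0.03 log units; within the scatter), so this position tolerates that small addition without a readable shift. Taking the group of 2 heavy atoms (1 carbon, 1 selenium) off an aromatic carbon of compound 2 and leaving a hydrogen atom there gives a 1.4-fold higher number from compound 2 to compound 4 (0.14 log units; within the scatter), so that group also makes no readable difference here. Methylsulfanyl in place of selenium gives an at least 1.1-fold lower number from compound 3 to compound 4 (0.05 log units; that floor lies within the scatter), which is only a floor, since compound 3 stands at a limit: the limit of > 100000 nM in this assay, at which 1 of the 4 values shown sits.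

On these data alone, the true number for compound 3 remains unknown. As far as these compounds go, whether a longer chain on the sulfur, or an amine in its place, would give a step beyond the scatter also stays open.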